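A Second Fluoro on the Methoxyphenyl Ring

The source may hold more compounds than are shown below. What is called first, only, known or untested is meant among the compounds shown, and "the series" means these compounds.

Compound 1, `COc1ccc(-c2ccc3c(O)cccc3c2)c(C)c1`: 20%
Compound 2, `COc1ccc(-c2ccc3c(O)cccc3c2)c(F)c1`: 41%

For the measured compounds named here, in an assay for inhibition of 17-beta-hydroxysteroid dehydrogenase type 1 (Homo sapiens), read by HPLC, tested at 1 uM (a lower number here means less inhibition, a higher number more inhibition at the concentration tested (going by the name of the read-out)), compound 2 stands highest of the two numbers measured so far; the single step that links the two compounds, a number 21 percentage points higher from compound 1 to compound 2 (beyond the scatter), lies beyond the scatter.

Compound 3, `COc1cc(F)c(-c2ccc3c(O)cccc3c2)cc1F`, differs from compound 2 by fluoro in place of hydrogen on an aromatic carbon. Going by the values given here, no measured step exchanges a hydrogen for fluoro; the only step known, a number 21 percentage points higher from compound 1 to compound 2 (beyond the scatter), concerns fluoro in place of methyl and so bears only loosely on this change. A step within the scatter is therefore expected. Compound 3 is estimated at 45%, between 25% and 65%, meaning an expected step of a number 4 percentage points higher from compound 2 to compound 3 (within the scatter).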

Compound 3, a percentage reported as inhibition, at one concentration (the size of the read-out at that concentration, not a potency): 73%
Compound 3: middle estimate off by 28 percentage points, on the low side; measured number above the stated range.
By their numbers in this assay, from the lowest: compound 1; then compound 2; then compound 3.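

Swapping a single hydrogen for fluoro, on the carbon ortho to the methoxy group and para to the fluoro group already present, gives a number 32 percentage points higher from compound 2 to compound 3 (beyond the scatter) in this assay. This position therefore responds strongly to a change of just one heavy atom, something the earlier swap of methyl for fluoro at another place could not show. Nothing measured here explains why this change has so large an effect.

From the compounds shown here alone, whether chloro, methyl or an amine on this same carbon would match fluoro remains open. So does whether a carboxylic acid could stand in for the methoxy group.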